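The source may report more compounds than this note shows. Statements on the series, on what has been measured and on what is new or still open speak of the compounds shown alone.

Compound 2 `C=CC[C@@H]1C[C@@H](c2ccc(Cl)c(Cl)c2)[C@H](NC(=O)c2cc(-c3c(Cl)cnn3C)c(Cl)o2)CN1`: 780 nM
Compound 3 `CNC(=O)C[C@@H]1C[C@@H](c2ccc(F)c(F)c2)[C@H](NC(=O)c2cc(-c3c(Cl)cnn3C)c(Cl)o2)CN1`: 1100 nM
Compound 1 `Cn1ncc(Cl)c1-c1cc(C(=O)N[C@@H]2CN[C@H](CC(=O)O)C[C@H]2c2ccc(Cl)c(Cl)c2)oc1Cl`: 4020 nM

In a functional assay on HCT-116 cells (Homo sapiens) for antiproliferative activity, read by sulforhodamine B assay, with a stated time of 72 h (a lower number here means a stronger inhibitor, a higher number a weaker inhibitor), compound 2 gives the lowest of the three numbers; compound 3 sits within the scatter of it, while compound 1 lies beyond it, the step being a 5.2-fold lower number from compound 1 to compound 2 (0.71 log units; beyond the scatter). Compound 4 `Cn1ncc(Cl)c1-c1cc(C(=O)N[C@@H]2CN[C@H](CC(=O)NC3CCC3)C[C@H]2c2ccc(Cl)c(Cl)c2)oc1Cl` differs from compound 2 by cyclobutylcarbamoyl in place of vinyl on a saturated chain carbon bound to a saturated ring carbon. Among the measured compounds shown here, the only measured step at the same saturated chain carbon, a 5.2-fold lower number from compound 1 to compound 2 (0.71 log units; beyond the scatter), runs from carboxy to vinyl and so does not map onto this change. For the measured compounds named here, compound 3 carries a carbamoyl at that carbon and gives 1100 nM, but it differs from compound 4 elsewhere as well, so no step between them is counted. Compound 4 is therefore expected to stay within the scatter of compound 2, a 1.2-fold higher number from compound 2 to compound 4 (0.06 log units; within the scatter), with an estimate of 900 nM (range 300 nM to 2700 nM).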

Compound 4, half-maximal inhibitory concentration: 430 nM
Estimate against measurement, compound 4: 2.1-fold (0.32 log units) above; low and high end bracket the measured number.
By their numbers in this assay, from the lowest: compounds 4, 2 and 3 (each within the scatter of the next, the first and the last beyond it); then compound 1.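

In this assay the saturated chain carbon bound to a saturated ring carbon accepts cyclobutylcarbamoyl, with its four-membered ring, as well as vinyl, the step being a 1.8-fold lower number from compound 2 to compound 4 (0.26 log units; within the scatter) at this position. Cyclobutylamino in place of hydroxy on a carbonyl carbon gives a 9.3-fold lower number from compound 1 to compound 4 (0.97 log units; beyond the scatter) and so shows that moving away from the carboxylic acid does not require losing the carbonyl. Going by these compounds, whether a primary amine or a longer chain at that carbonyl carbon would hold these numbers stays open. Nothing given here accounts for these differences.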